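A few compounds are considered here, and "the series" means these few. Any claim that something is new, unique, unknown or untested is made for them only; others in the source may bear on it.

Measured compounds:
- compound 1 `Cc1cc(Br)ccc1NC(=O)COc1ccc2cc(/C=C3/SC(=O)NC3=O)ccc2c1` — 7400 nM in an assay on isolated protein for inhibition of histone deacetylase 8 (Homo sapiens), with a stated time of 1 h; a lower number here means a stronger inhibitor, a higher number a weaker inhibitor
- compound 2 `O=C(COc1ccc2cc(/C=C3/SC(=O)NC3=O)ccc2c1)Nc1ccc([N+](=O)[O-])cc1` — 4000 nM in this assay
- compound 3 `O=C(COc1ccc2cc(/C=C3/SC(=O)NC3=O)ccc2c1)Nc1ccc(Cl)c(Cl)c1` — in this assay compound 3 reaches only a limit, > 50000 nM

Among the two numbers that are not limits, compound 1 holds the higher one; its nearest neighbour is compound 2, and the step of a 1.9-fold lower number from compound 1 to compound 2 (0.27 log units; within the scatter) stays within the scatter. The step of an at least 6.7-fold higher number from compound 1 to compound 3 (0.82 log units; beyond the scatter) is larger, and for compound 3 it is marked by the limit of > 50000 nM in this assay, at which 1 of the 3 values shown sits. Compound 4 `Cc1cccc(NC(=O)COc2ccc3cc(/C=C4/SC(=O)NC4=O)ccc3c2)n1` differs from compound 1 by 6-methylpyridin-2-yl in place of 4-bromo-2-methylphenyl on an amide-type nitrogen. Among the compounds with values here, no measured step shows this particular change; the two steps that alter the same group run in opposite directions, a 1.9-fold lower number from compound 1 to compound 2 (0.27 log units; within the scatter) within the scatter and an at least 12-fold higher number from compound 2 to compound 3 (1.09 log units; beyond the scatter) well beyond it. The step of a 1.4-fold higher number from compound 1 to compound 4 (0.13 log units; within the scatter) is therefore expected to be small, with the chance of a limit kept in mind. For compound 4 a value of 10000 nM is estimated, expected between 3000 nM and 40000 nM.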

Compound 4, half-maximal inhibitory concentration: 7500 nM
For compound 4 the middle estimate is 1.3-fold (0.12 log units) above the measured one, and the stated range covers the measured number.
By their numbers in this assay, from the lowest: compounds 2, 1 and 4 (each within the scatter of the next). At a limit, above all of these: compound 3.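

Replacing 4-bromo-2-methylphenyl with 6-methylpyridin-2-yl, a ring with 1 hetero atom and 1 hydrogen-bond acceptor, gives no separable difference in this assay, with a 1.0-fold higher number from compound 1 to compound 4 (0.01 log units; within the scatter). The comparison with the 4-nitrophenyl group reads the same, with a 1.9-fold higher number from compound 2 to compound 4 (0.27 log units; within the scatter), so three different rings on this amide-type nitrogen now lie within the scatter of one another. The 3,4-dichlorophenyl group alone stands apart, with an at least 6.6-fold lower number from compound 3 to compound 4 (0.82 log units; beyond the scatter), and that step rests on a limit rather than a number: the limit of > 50000 nM in this assay, at which 1 of the 4 values shown sits.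

The compounds shown leave open whether the level depends on the methyl group of 6-methylpyridin-2-yl, since the plain pyridin-2-yl ring does not appear among them. They also do not tell how an amine or a carboxylic acid on this ring would read, or why 3,4-dichlorophenyl departs from the other rings.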